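Amide to sulfonamide on the aryl nitrogen: thermal shift

The compounds below may be only part of what the source reports. "The series", "measured", "known", "first", "only" and "open" are said of these compounds alone.

Measured compounds:
compound 1, `CC(C)(C)c1cc(NC(=O)Nc2ccc(Cl)cc2)n(-c2ccc(C#N)cc2)n1`, 2.2 degrees C
compound 2, `CC(C)C(=O)Nc1ccc(-n2nc(C(C)(C)C)cc2NC(=O)Nc2ccc(Cl)cc2)cc1`, 5.1 degrees C

Among the measured compounds shown here, in an assay on isolated protein for inhibition of serine/threonine-protein kinase 10 (Homo sapiens), read by thermal shift assay, tested at 10 uM (a higher number here means that the compound stabilises the target more against heat, a lower number that the compound stabilises the target less), compound 2 gives 5.1 degrees C, the higher of the two numbers known so far. For the measured compounds named here, its only neighbour is compound 1, which in this assay gives 2.2 degrees C; the step of a number 2.9 degrees C higher from compound 1 to compound 2 (beyond the scatter) is the one change seen at that position of the core.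

Compound 3, `CC(C)(C)c1cc(NC(=O)Nc2ccc(Cl)cc2)n(-c2ccc(NS(C)(=O)=O)cc2)n1`, has not yet been run in this assay. It differs from compound 2 by methylsulfonyl in place of isopropylcarbonyl on a nitrogen on an aromatic ring, that is, on a nitrogen on an aromatic ring whose other neighbours are aromatic carbon.

Going by the values given here, only the step of a number 2.9 degrees C higher from compound 1 to compound 2 (beyond the scatter) bears on this change, and it bears only loosely: it shows that putting a substituted amino group in place of cyano at this position raised the shift by a modest amount, but no measured pair exchanges one group on that nitrogen for another. The change from isopropylcarbonyl to methylsulfonyl is therefore expected to move the shift little, with any change more likely downward than upward. Compound 3 is estimated at 4.5 degrees C, range 2.5 degrees C to 6.5 degrees C, an expected step of a number 0.60 degrees C lower from compound 2 to compound 3 (within the scatter).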

Compound 3, shift of the target's melting temperature: 8.9 degrees C
Compound 3: the middle estimate sits 4.4 degrees C below what was measured; measured number outside the range, above it.
By their numbers in this assay, from the lowest: compound 1; then compound 2; then compound 3.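

The earlier compounds shown here showed only that replacing cyano with a substituted amino group raised the number; compound 3 shows that the group carried on that nitrogen also counts. In this assay, among the compounds shown here, methylsulfonyl in place of isopropylcarbonyl gives a number 3.8 degrees C higher from compound 2 to compound 3 (beyond the scatter), and with methanesulfonamido in place of cyano on an aromatic carbon the result is a number 6.7 degrees C higher from compound 1 to compound 3 (beyond the scatter), the only one of the three steps that counts as large, leaving compound 3 with the highest number of the three. Nothing available here accounts for the difference between the two groups on the nitrogen.

With a single sulfonyl group and a single carbonyl group on this nitrogen, the compounds shown do not separate the exchange of carbonyl for sulfonyl from the change of the attached chain, so an acetyl group or a longer chain such as ethylsulfonyl would be needed to tell the two apart. On these data alone, it also remains open whether the number holds with a methyl group on that nitrogen in place of its hydrogen, or with phenylsulfonyl in place of methylsulfonyl.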